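Swapping fluoro for trifluoromethyl on a biaryl tail

The compounds below may be only part of what the source reports. "The series", "measured", "known", "first", "only" and "open" are said of these compounds alone.

Measured compounds in a physicochemical assay for lipophilicity, read by HPLC, at pH 7.5; a higher number here means a more lipophilic compound, a lower number a more polar compound:
- compound 1 `CC[C@@H](Nc1c(C#N)c(-c2ccc(-c3ccccc3F)cc2)nc2cnccc12)C(N)=O`: 2.7
- compound 2 `CCOc1ccccc1-c1ccc(-c2nc(NC(C)C(=O)O)c3ccncc3n2)cc1`: 2.1
- compound 3 `CCOc1ccccc1-c1ccc(-c2nc3cnccc3c(NC(COC)C(N)=O)c2C#N)cc1`: 2.8

Compound 1 and compound 3 lie within the usual scatter of each other, so neither can be called more lipophilic. Compound 2 lies lower than compound 1 by a gap beyond the scatter. Compound 4 `CC[C@@H](Nc1c(C#N)c(-c2ccc(-c3ccccc3C(F)(F)F)cc2)nc2cnccc12)C(N)=O` is not yet measured; it differs from compound 1 in one place: trifluoromethyl in place of fluoro on an aromatic carbon. This reads as 2-fluorophenyl becoming 2-(trifluoromethyl)phenyl. No two measured compounds differ by exactly this change, so the size of the step is not shown here. Compound 4 is expected to rise in this assay by a number 0.70 log units higher from compound 1 to compound 4 (beyond the scatter), a step beyond the scatter. Compound 4 is estimated at 3.4, between 2.9 and 3.9.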

Compound 4, distribution coefficient: 3.1
Compound 4: the middle estimate sits 0.30 log units above what was measured; low and high end bracket the measured number.
By their numbers in this assay, from the lowest: compound 2; then compounds 1, 3 and 4 (each within the scatter of the next, the first and the last beyond it).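

Putting trifluoromethyl in place of fluoro on this aromatic carbon gives a modest step in this assay (a number 0.40 log units higher from compound 1 to compound 4 (beyond the scatter)). Going by these compounds alone, this is the first pair here that differs in one place only, so the size of this change at this position can now be read directly. No measurement shown here explains why the step has this size.

Going by these compounds, a chloro or methyl group on the same carbon remains open, as does where either would fall relative to fluoro and trifluoromethyl. On these data alone, whether the step stays the same size with a carboxylic acid in place of the primary amide is also open.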